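The compounds below may be only part of what the source reports. "The series", "measured", "known", "first", "only" and "open" are said of these compounds alone.

Compound 1, `Cc1cc(COc2ccccc2)nc(-c2ccccn2)n1`: 794 nM
Compound 2, `Cc1cc(COc2cccc(Cl)c2)nc(-c2ccccn2)n1`: 398 nM
Compound 3, `Cc1cc(COc2ccccc2F)nc(-c2ccccn2)n1`: 398 nM

In a functional assay on cells for antagonist activity at Free fatty acid receptor 1 (Homo sapiens), read by TR-FRET and inositol phosphate accumulation, with a stated time of 2 h (a lower number here means a stronger inhibitor, a higher number a weaker inhibitor), compound 1 gives 794 nM, the highest of the three numbers, although its distance to compound 2 and to compound 3 stays within the scatter. Compound 4, `Cc1cc(COc2ccc(F)cc2)nc(-c2ccccn2)n1`, differs from compound 1 by fluoro in place of hydrogen on an aromatic carbon. Among the measured compounds shown here, two measured steps bear on this change: a 2.0-fold lower number from compound 1 to compound 2 (0.30 log units; within the scatter) and a 2.0-fold lower number from compound 1 to compound 3 (0.30 log units; within the scatter), each a halogen entering an aromatic carbon of the same ring and each within the scatter. On that basis compound 4 is expected to show no step beyond the scatter, at most a modest drift toward a lower number, giving an expected 1.4-fold lower number from compound 1 to compound 4 (0.15 log units; within the scatter). Compound 4 is therefore estimated at 560 nM, within a range of 250 nM to 1300 nM.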

Compound 4, half-maximal inhibitory concentration in the Free fatty acid receptor 1 assay: 631 nM
Beside the measured number, compound 4's estimate is 1.1-fold (0.05 log units) below it, within the range that was stated.
By their numbers in the Free fatty acid receptor 1 assay, from the lowest: compounds 2, 3, 4 and 1 (each within the scatter of the next).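

In the Free fatty acid receptor 1 assay compound 4 gives 631 nM. In the Free fatty acid receptor 1 assay, fluoro on an aromatic carbon para to a large group gives a 1.3-fold lower number from compound 1 to compound 4 (0.10 log units; within the scatter) and, set against the other halogen placements, a 1.6-fold higher number from compound 3 to compound 4 (0.20 log units; within the scatter) and a 1.6-fold higher number from compound 2 to compound 4 (0.20 log units; within the scatter), so this position, too, stays within the scatter and no placement among these separates from the others. In a physicochemical assay for lipophilicity, at pH 7.4 (on this read-out higher numbers stand for higher lipophilicity and lower numbers for lower lipophilicity), compound 1 gives 2.7 and compound 4 gives 3; the same change gives a number 0.30 log units higher from compound 1 to compound 4 (within the scatter) and also remains within the scatter. No measurement shown accounts for these small steps.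

The ring carries only fluoro or chloro here. From the compounds shown here alone, whether an amine or a carboxylic acid at this position would produce a step beyond the scatter remains open.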